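A Nitro Group Enters a Weakly Active Thiosemicarbazone

The compounds below may be only part of what the source reports. "The series", "measured", "known", "first", "only" and "open" are said of these compounds alone.

Two related thiosemicarbazones share one core and were tested in a functional assay on NCI-H460 cells (Homo sapiens) for inhibition, read by sulforhodamine B assay, with a stated time of 48 h; a lower number here means a stronger inhibitor of growth, a higher number a weaker inhibitor of growth. Compound 1 `CC1=CC[C@H](C(C)(C)NC(=S)N/N=C/c2ccc[nH]2)CC1` carries a pyrrole ring at the imine end and in this assay compound 1 gives 57500 nM. Compound 2 `CC1=CC[C@H](C(C)(C)NC(=S)N/N=C(\C)c2ccccc2)CC1` carries a phenyl ring with a methyl on the imine carbon instead. For compound 2 this assay reports only a limit, > 100000 nM, so no number is known for it. Compound 2 therefore stands at the weak end of what is shown, at the limit of > 100000 nM in this assay, at which 1 of the 2 values shown sits, and the two values cannot be ordered any further than that.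

Compound 3 `CC1=CC[C@H](C(C)(C)NC(=S)N/N=C(\C)c2ccc([N+](=O)[O-])cc2)CC1` differs from compound 2 in one place: nitro in place of hydrogen on an aromatic carbon. Among the compounds with values here, no measured pair of compounds shows what such an exchange does here, so the size of the step is not known from the data. From compound 2 a small gain is expected, and the step from compound 2 to compound 3 is estimated as an at least 1.1-fold lower number from compound 2 to compound 3 (0.04 log units; that floor lies within the scatter). Compound 3 is expected to sit near 90000 nM, within a range from 35000 nM to 200000 nM.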

Compound 3, concentration for total growth inhibition: 83700 nM
The estimate for compound 3 lay 1.1-fold (0.03 log units) above the measured number; the measured number falls inside the stated range.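

In this assay compound 3 gives 83700 nM, a true number rather than a limit, so a change at this place on the six-membered aromatic ring, para to a large group, can now be read against a measured value. Nitro in place of hydrogen on an aromatic carbon gives an at least 1.1-fold lower number from compound 2 to compound 3 (0.07 log units; that floor lies within the scatter), and that figure is only a floor: the true step may be this small or much larger, and on this evidence alone even a floor within the scatter cannot be called a clear gain. The open end of the step comes from compound 2, whose entry is a limit and not a number: the limit of > 100000 nM in this assay, at which 1 of the 3 values shown sits.

The compounds shown leave open whether nitro itself matters at this place or whether another group, such as an amine, a carboxylic acid or a methoxy group, would give a similar or lower number. Going by these compounds, they also leave open whether the same exchange would carry over to the pyrrole ring of compound 1, and what lies behind the step remains unknown.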